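The compounds below may be only part of what the source reports. "The series", "measured", "known", "first", "only" and "open" are said of these compounds alone.

Measured compounds:
Compound 1 `COc1cc(NC(C)CCCNC(=O)OC(C)(C)C)c2nc(C(F)(F)F)cc(C)c2c1-c1ccc(C(F)(F)F)cc1` gives 0.5 h in an ADME assay on microsomes (Homo sapiens) for metabolic stability, read by LC-MS; on this read-out higher numbers stand for a longer-lived compound and lower numbers for a shorter-lived compound.
Compound 2 `COc1cccc(-c2c(OC)cc(NC(C)CCCNC(=O)OC(C)(C)C)c3nc(C(F)(F)F)cc(C)c23)c1` gives 0.15 h in this assay.

Compound 2 has the lowest of the two numbers in this assay; the only other compound, compound 1, stands higher, as shown by a 3.3-fold lower number from compound 1 to compound 2 (0.52 log units; beyond the scatter). Compound 3 `COc1cc(NC(C)CCCNC(=O)OC(C)(C)C)c2nc(C(F)(F)F)cc(C)c2c1-c1cccc(C)c1` is not yet measured. It differs from compound 2 by methyl in place of methoxy on an aromatic carbon, the same difference cut one bond further out reading 3-methoxyphenyl to 3-methylphenyl.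

Within the data shown here, only one measured step bears on this place: the one from compound 1 to compound 2 swapped the whole aryl group, 3-methoxyphenyl in place of 4-(trifluoromethyl)phenyl, and gave a 3.3-fold lower number from compound 1 to compound 2 (0.52 log units; beyond the scatter), a modest change beyond the scatter. The change to compound 3 is smaller, exchanging a single substituent on that aryl ring, so a step of at most modest size is expected in this assay, with the direction uncertain; a small rise seems somewhat more likely than a fall, since compound 2 sits at the bottom of the two numbers shown.

The expected step from compound 2 to compound 3 is a 2.0-fold higher number from compound 2 to compound 3 (0.30 log units; within the scatter). Compound 3 is therefore estimated at 0.3 h, with a range from 0.12 h to 0.75 h.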

Compound 3, half-life: 0.217 h
Compound 3: the middle estimate sits 1.4-fold (0.14 log units) above what was measured; the measured number falls inside the stated range.
By their numbers in this assay, from the lowest: compounds 2 and 3 (each within the scatter of the next); then compound 1.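

In this assay, methyl in place of methoxy on the aryl ring, meta to a large group, gives a 1.4-fold higher number from compound 2 to compound 3 (0.16 log units; within the scatter) and so leaves the two compounds indistinguishable; at this place on the ring, the exchange of these two small groups does not register as a real difference. Compound 1 also stands apart from the 3-methylphenyl compound, with a 2.3-fold lower number from compound 1 to compound 3 (0.36 log units; beyond the scatter) for this assay, so the gap first seen with the 3-methoxyphenyl compound is not tied to methoxy alone and appears with both of these ring patterns. No measurement shown here accounts for either step.

The compounds shown leave open whether the gap to compound 1 follows the trifluoromethyl group itself or the place it occupies on the ring, a question that a 3-(trifluoromethyl)phenyl ring or a 4-methylphenyl ring could separate. Also open, from the compounds shown here alone, is how a chlorine atom, a nitrile or an amine on this ring would fare in this assay against the groups compared so far.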